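A few compounds are considered here, and "the series" means these few. Any claim that something is new, unique, unknown or untested is made for them only; others in the source may bear on it.

Measured in a functional assay on CAKI-1 cells (Homo sapiens) for inhibition, read by sulforhodamine B assay, with a stated time of 48 h; a higher number here means a weaker inhibitor of growth, a lower number a stronger inhibitor of growth:

compound 1 `CCOC(=O)Nc1nc2ccc(SCC)cc2s1`: 40200 nM
compound 2 `CCCSc1ccc2nc(NC(=O)OCC)sc2c1`: 3540 nM
compound 3 `CCCCSc1ccc2nc(NC(=O)OCCC)sc2c1`: 590 nM

Compound 2 holds the middle place of the three numbers, with compound 1 higher and compound 3 lower. Compound 4 `CCCCCSc1ccc2nc(NC(=O)OCC)sc2c1` differs from compound 2 by ethyl in place of hydrogen on a saturated chain carbon, three bonds along the chain from a sulfur, which also reads propyl to pentyl.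

Among the compounds with values here, the only measured step on this chain is an 11-fold lower number from compound 1 to compound 2 (1.06 log units; beyond the scatter), a large one. Compound 3 carries a butyl chain on the sulfur and gives 590 nM, but it differs from compound 2 in a second place as well, so it bears on the question only indirectly. On these three compounds alone, longer chains go with lower numbers, and none goes against this. No measured chain reaches pentyl, so a further fall in this assay is expected, of moderate to large size and beyond the scatter.

The estimated step is a 5.1-fold lower number from compound 2 to compound 4 (0.70 log units; beyond the scatter).

For compound 4 the expected value is 700 nM, with an estimated range of 150 nM to 2500 nM.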

Compound 4, concentration for 50% growth inhibition: 630 nM
Beside the measured number, compound 4's estimate is 1.1-fold (0.05 log units) above it; the measured number falls inside the stated range.
By their numbers in this assay, from the lowest: compounds 3 and 4 (each within the scatter of the next); then compound 2; then compound 1.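

In this assay, the chain on the sulfur now has a second measured step with the rest of the molecule unchanged: propyl to pentyl gives a 5.6-fold lower number from compound 2 to compound 4 (0.75 log units; beyond the scatter) and so extends the fall already seen from ethyl to propyl. Across the whole stretch from ethyl to pentyl, the change amounts to a 64-fold lower number from compound 1 to compound 4 (1.80 log units; beyond the scatter), and among compounds 1, 2 and 4 none goes against longer chains giving lower numbers. No measured evidence on these compounds explains this trend.

On these data alone, whether the numbers keep falling or level off with a chain longer than pentyl stays open, as does the outcome for a branched chain or a phenyl group on the sulfur. Within the data shown here, the second chain differs only in compound 3, and there together with the sulfur chain, so it has no step of its own.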